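The compounds below may be only part of what the source reports. "The series", "measured", "known", "first", "only" and "open" are said of these compounds alone.

Of the compounds shown here, three so far share one core and are compared in a single setting. Compound 1 `O=S(=O)(c1ccc(Br)cc1)c1nc2ccccc2nc1N1CCCC1` carries a 4-bromophenyl group and a pyrrolidin-1-yl ring. In a functional assay on HCT-116 cells (Homo sapiens) for cytotoxicity, read by MTT assay, with a stated time of 72 h (a lower number here means a stronger inhibitor, a higher number a weaker inhibitor), compound 1 gives 37700 nM. Compound 2 `O=S(=O)(c1ccc(F)cc1)c1nc2ccccc2nc1N1CCCC1` differs from compound 1 by fluoro in place of bromo on an aromatic carbon. In this assay compound 2 gives 20600 nM, so that a 1.8-fold lower number from compound 1 to compound 2 (0.26 log units; within the scatter). Compound 3 `O=S(=O)(c1ccc(Br)cc1)c1nc2ccccc2nc1N1CCCC(O)C1` keeps the 4-bromophenyl group of compound 1 but has 3-hydroxypiperidin-1-yl in place of pyrrolidin-1-yl. In this assay compound 3 gives 2110 nM, and an 18-fold lower number from compound 1 to compound 3 (1.25 log units; beyond the scatter), the lowest number among the three, beyond the scatter to both others.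

Compound 4 `O=S(=O)(c1ccc(F)cc1)c1nc2ccccc2nc1N1CCCC(O)C1` has not yet been measured. It stands to compound 3 as compound 2 stands to compound 1: the change is fluoro in place of bromo on an aromatic carbon, the same change that was made from compound 1 to compound 2, on the same kind of carbon of the same kind of ring. The cores on which the two instances sit differ by 3-hydroxypiperidin-1-yl in place of pyrrolidin-1-yl on an aromatic carbon. When this change was made before, the step was small; it gave a 1.8-fold lower number from compound 1 to compound 2 (0.26 log units; within the scatter), within the scatter. Resting on that earlier step alone, the expected step to compound 4 is a 1.5-fold lower number from compound 3 to compound 4 (0.18 log units; within the scatter). Compound 4 is therefore estimated at 1400 nM, most likely between 600 nM and 3500 nM, the numbers to be tested against the result.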

Compound 4, half-maximal inhibitory concentration: 5500 nM
For compound 4 the middle estimate is 3.9-fold (0.59 log units) below the measured one; the measured number lies above the stated range.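

In this assay, fluoro in place of bromo on the core carrying 3-hydroxypiperidin-1-yl gives a 2.6-fold higher number from compound 3 to compound 4 (0.42 log units; beyond the scatter), so this step lies beyond the scatter, whereas the same change on the core carrying pyrrolidin-1-yl did not, and its size did not carry from one core to the other: the same change on two cores in this assay, a 1.8-fold lower number (0.26 log units; within the scatter) from compound 1 to compound 2 and a 2.6-fold higher number (0.42 log units; beyond the scatter) from compound 3 to compound 4, 4.8-fold (0.68 log units) apart, beyond the scatter of two such steps. Read the other way, 3-hydroxypiperidin-1-yl in place of pyrrolidin-1-yl gives a lower number with both aryl groups, including a 3.7-fold lower number from compound 2 to compound 4 (0.57 log units; beyond the scatter), but the size of that step also depends on the partner group: the same change on two cores in this assay, an 18-fold lower number (1.25 log units; beyond the scatter) from compound 1 to compound 3 and a 3.7-fold lower number (0.57 log units; beyond the scatter) from compound 2 to compound 4, 4.8-fold (0.68 log units) apart, beyond the scatter of two such steps. The four compounds thus show that the two changes do not act independently here, but they cannot show the reason for this, and the finding rests on a single pair of steps for each change in one cell assay.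

The compounds shown leave open whether the gain belongs to the hydroxy group or to the larger ring, a question that piperidin-1-yl without the hydroxy group and 3-hydroxypyrrolidin-1-yl would address. They also leave open how chloro or methoxy on the same aromatic carbon would behave on either core.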